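Adding butyl to the benzyl end of compound 3

The source may hold more compounds than are shown below. What is called first, only, known or untested is meant among the compounds shown, and "the series" means these compounds.

In a functional assay on HCT-116 cells (Homo sapiens) for antiproliferative activity, read by WST assay, with a stated time of 72 h (on this read-out higher numbers stand for weaker inhibition of growth and lower numbers for stronger inhibition of growth), compound 3 `O=C(NO)c1cnc(N2C[C@@H]3[C@H](C2)[C@H]3NCc2ccccc2)nc1` gives 120 nM. This is the lowest of three numbers and lies beyond the scatter from the other two: compound 1 `O=C(NO)c1cnc(N2C[C@@H]3[C@H](C2)[C@H]3NC(=O)c2ccc3ccccc3c2)nc1` gives 410 nM and compound 2 `O=C(NO)c1cnc(N2C[C@@H]3[C@H](C2)[C@H]3NC(=O)c2ccccc2)nc1` gives 5100 nM.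

Compound 4 `CCCCc1ccc(CN[C@H]2[C@@H]3CN(c4ncc(C(=O)NO)cn4)C[C@@H]32)cc1` is compound 3 with butyl in place of hydrogen on an aromatic carbon, para to a large group (butyl in place of hydrogen on an aromatic carbon).

Within the data shown here, only one single change has been measured, a 43-fold lower number from compound 2 to compound 3 (1.63 log units; beyond the scatter). That step is large, but it swaps benzoyl for benzyl on an amine nitrogen, so it says nothing direct about butyl. A weaker hint comes from compound 1 at 410 nM, whose larger aromatic group goes with a lower number than compound 2 at 5100 nM. On that single pair, a modest move towards stronger growth inhibition is expected, far smaller than the benzyl step.

The estimated change is a 2.4-fold lower number from compound 3 to compound 4 (0.38 log units; beyond the scatter). For compound 4 the expected value is 50 nM, with an estimated range from 12 nM to 200 nM.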

Compound 4, concentration for 50% growth inhibition: 410 nM
The estimate for compound 4 lay 8.2-fold (0.91 log units) below the measured number; the measured number lies above the stated range.
By their numbers in this assay, from the lowest: compound 3; then compounds 1 and 4 (each within the scatter of the next); then compound 2.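

At this position, on an aromatic carbon para to a large group, butyl in place of hydrogen does not bring stronger inhibition of growth: in this assay the change gives a 3.4-fold higher number from compound 3 to compound 4 (0.53 log units; beyond the scatter), a modest step towards weaker inhibition. Among these compounds, this is the first measured change on the six-membered aromatic ring of the benzyl end, and it shows that the ring can carry this chain with only a modest loss. No measurement here explains this loss.

One butyl compound cannot show whether the number follows chain length, so a methyl or a longer chain at this same carbon would be needed to test that. Going by these compounds, it also remains open whether an amine or a carboxylic acid at this carbon would give a lower number than hydrogen.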